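The source may report more compounds than this note shows. Statements on the series, on what has been measured and on what is new or still open speak of the compounds shown alone.

Measured compounds:
Compound 1: `Cn1nc2c(=O)n(CC3(O)CCN(Cc4ccc(-c5ccco5)cc4Cl)CC3)cnc2c1-c1ccc(C(F)(F)F)cc1` gives 530 nM
Compound 2: `Cn1nc2c(=O)n(CC3(O)CCN(Cc4ccc(-c5ccsc5)cc4Cl)CC3)cnc2c1-c1ccc(CN)cc1` gives 59.5 nM
Compound 3: `CCCNCc1ccc(-c2c3ncn(CC4(O)CCN(Cc5ccc(-c6ccco6)cc5Cl)CC4)c(=O)c3nn2C)cc1` gives 43.9 nM

All three numbers come from an assay on isolated protein for inhibition of ubiquitin carboxyl-terminal hydrolase 7 (Homo sapiens), with stated times of 30 min and 2 h; a lower number here means a stronger inhibitor, a higher number a weaker inhibitor. On those numbers compound 2 stands second highest of the three; the pair compound 2 and compound 3 are not separated, since their gap lies within the usual scatter, whereas compound 1 sits well apart from compound 2, beyond the scatter.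

Only one measured step joins two of these compounds at a single site: a 12-fold lower number from compound 1 to compound 3 (1.08 log units; beyond the scatter). That change sits on the aryl group attached to the shared core, not on the chloro-bearing ring, so it tells nothing directly about the position at issue here.

Compound 4, `Cn1nc2c(=O)n(CC3(O)CCN(Cc4ccc(-n5cccn5)cc4Cl)CC3)cnc2c1-c1ccc(CN)cc1`, differs from compound 2 in one place: 1H-pyrazol-1-yl in place of thiophen-3-yl on an aromatic carbon. For the measured compounds named here, no measured pair among compounds 1, 2 and 3 alters that ring, so there is no step to weigh for this exchange, and the expectation rests on compound 2 alone. The change is expected to give a step of a 1.1-fold higher number from compound 2 to compound 4 (0.04 log units; within the scatter), that is, nothing beyond the scatter in either direction. Compound 4 is therefore estimated at 65 nM in this assay, with a range from 25 nM to 170 nM.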

Compound 4, half-maximal inhibitory concentration: 233 nM
Compound 4: the middle estimate sits 3.6-fold (0.55 log units) below what was measured; measured number outside the range, above it.
By their numbers in this assay, from the lowest: compounds 3 and 2 (each within the scatter of the next); then compound 4; then compound 1.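

In this assay, for the compounds shown here, the group on the chloro-bearing ring, at the place para to a large group, turns out not to be freely exchangeable: putting 1H-pyrazol-1-yl in place of thiophen-3-yl gives a 3.9-fold higher number from compound 2 to compound 4 (0.59 log units; beyond the scatter) and so provides the first reading of this position, since the only earlier single-site step lay on the aryl group attached to the shared core. The two groups have the same count of heavy atoms and each is one five-membered aromatic ring, so keeping the ring size and the heavy-atom count does not by itself hold the number within the scatter. What separates them in the count is the hetero atoms, one sulfur leaving and two nitrogens entering, along with one more hydrogen-bond acceptor, although this single pair cannot show which of these differences matters.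

Still open, on these data alone, is how other groups at this place would read against thiophen-3-yl, for instance furan-2-yl on the same aminomethyl background, a phenyl ring, a pyridine ring or an amine, and whether the step holds with (propylamino)methyl on the other aryl group. No measurement offered here accounts for the step between these two groups.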